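Benzylamides of amino acids in the mouse formalin test

The compounds below may be only part of what the source reports. "The series", "measured", "known", "first", "only" and "open" are said of these compounds alone.

Measured so far:
compound 1, `C#CCOCC(N)C(=O)NCc1ccccc1`, 74 mg/kg
compound 2, `CSCC[C@@H](N)C(=O)NCc1ccccc1`, > 76 mg/kg
compound 3, `CCC[C@H](N)C(=O)NCc1ccccc1`, 100 mg/kg

All three share one core, an amino acid joined as an amide to benzylamine, and differ only in the side chain on the saturated chain carbon bound to an amine nitrogen and a carbonyl carbon. In a functional assay on the whole organism (strain NMRI) for inhibition, with Mus musculus as the target, in the formalin test, with a stated time of 30 min (on this read-out higher numbers stand for an effect only at larger amounts of compound and lower numbers for an effect already at smaller amounts), compound 1 gives 74 mg/kg and compound 3 gives 100 mg/kg; these two numbers lie within the scatter of each other, so neither can be called the more active. For compound 2 this assay gave only a limit, > 76 mg/kg, not a number (the limit of > 76 mg/kg in this assay, at which 1 of the 3 values shown sits).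

Compound 4, `CCC(C)C(N)C(=O)NCc1ccccc1`, has not been measured. It differs from compound 1 as follows: sec-butyl in place of (propargyloxy)methyl on a saturated chain carbon bound to an amine nitrogen and a carbonyl carbon. The side chain of compound 4 is close to the propyl of compound 3, and since compound 3 gives 100 mg/kg, no step beyond the scatter is expected. The expected step is a 1.4-fold higher number from compound 1 to compound 4 (0.13 log units; within the scatter). Compound 4 is estimated at 100 mg/kg, with a range from 50 mg/kg to 200 mg/kg.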

Compound 4, dose for half-maximal effect: > 22 mg/kg
Compound 4 ended at the assay's limit; the forecaster's own chance of this, stated with the estimate: 30%; the middle value lies beyond the limit too.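

In this assay, among the compounds shown here, compound 4 gives > 22 mg/kg and this is a limit, not a number, so no step from compound 1 to compound 4 can be read. The compounds shown leave open whether sec-butyl or (propargyloxy)methyl gives an effect at smaller amounts of compound.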